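A few compounds are considered here, and "the series" means these few. Any claim that something is new, unique, unknown or untested is made for them only; others in the source may bear on it.

Of the compounds shown here, three built on one shared core have been read in a functional assay on K562 cells (Homo sapiens) for inhibition, read by trypan blue exclusion, with a stated time of 24 h, tested at 10 uM; on this read-out higher numbers stand for more inhibition of growth at the one concentration tested and lower numbers for less inhibition of growth. Compound 1 `Cc1ccc(OCC(=O)Nc2ccccc2C(N)=O)cc1` gives < 10%, and this is a limit of the assay, not a number. Compound 2 `Cc1ccc(OCC(=O)Nc2ccc(Cl)cc2C(N)=O)cc1` gives 24.1%. For the measured compounds named here, the single measured step between two of them is a number at least 14.1 percentage points higher from compound 1 to compound 2 (beyond the scatter), with chloro in place of hydrogen on an aromatic carbon. Compound 3 `Cc1ccc(NC(=O)COc2ccccc2C)c(C(N)=O)c1` gives 45.6%, the higher of the two actual numbers, and its gap to compound 2 lies beyond the scatter.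

Compound 4 `Cc1ccc(OCC(=O)Nc2ccc(C)cc2C(N)=O)cc1` has the same atoms as compound 3, joined differently: 4-methylphenyl in place of 2-methylphenyl on an oxygen on a saturated carbon. This places 4-methylphenyl in place of 2-methylphenyl on an oxygen on a saturated carbon. Going by the values given here, no measured step isolates this exchange, and the one step available concerns a change elsewhere in the structure, so it bears on the question only indirectly. The closest guide is compound 2, which carries the same 4-methylphenyl and gives 24.1%. On that slender basis a fall beyond the scatter is expected in this assay, and the expected step is a number 15.6 percentage points lower from compound 3 to compound 4 (beyond the scatter). For compound 4 the estimated value is 30%, with an expected range from 12% to 50%.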

Compound 4, percent growth inhibition at one concentration: 30.3%
Compound 4: the middle estimate sits 0.3 percentage points below what was measured; the range from low to high includes it.
By their numbers in this assay, from the lowest: compounds 2 and 4 (each within the scatter of the next); then compound 3. At a limit, below all of these: compound 1.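

a number 15.3 percentage points lower from compound 3 to compound 4 (beyond the scatter) in this assay shows that 4-methylphenyl in place of 2-methylphenyl on an oxygen on a saturated carbon matters here, even though the two compounds hold the same atoms; the earlier steps had not isolated any change at this position. The change elsewhere in the structure adds a second point: methyl in place of chloro on an aromatic carbon gives a number 6.2 percentage points higher from compound 2 to compound 4 (within the scatter), so this exchange shows no separable change, while methyl in place of hydrogen on that carbon gives a number at least 20.3 percentage points higher from compound 1 to compound 4 (beyond the scatter), in the same direction as the earlier chloro step. Compound 1 stands at a limit of the assay and not at a number: the limit of < 10% in this assay, at which 1 of the 4 values shown sits.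

The compounds shown leave open whether 2-methylphenyl keeps its advantage over 4-methylphenyl when chloro or hydrogen replaces the methyl on the aromatic carbon changed in compound 2. They also leave open what 3-methylphenyl or plain phenyl would give on that oxygen, and what an amine or a carboxylic acid would give in place of the methyl.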